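A few compounds are considered here, and "the series" means these few. Any claim that something is new, unique, unknown or untested is made for them only; others in the source may bear on it.

In an ADME assay on microsomes from liver (Rattus norvegicus) for metabolic stability, read by LC-MS, using NADPH, with a stated time of 10 min, tested at 0.1 uM (a lower number here means slower removal, a higher number faster removal of the compound), the three measured compounds stand as follows:
compound 1 `COc1ccc(F)cc1N1C(=O)CSC1c1cccc(C(=O)NCCCCn2cccn2)c1` gives 1470 mL.min-1.g-1
compound 2 `O=C(NCCCCn1cccn1)c1cccc(C2SCC(=O)N2c2ccccn2)c1` gives 506 mL.min-1.g-1
compound 3 `Cc1ccnc(N2C(=O)CSC2c2cccc(C(=O)NCCCCn3cccn3)c2)c1` gives 1020 mL.min-1.g-1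

Compound 3 holds the second highest of these three numbers, yet both the step of a 1.4-fold lower number from compound 1 to compound 3 (0.16 log units; within the scatter) and the step of a 2.0-fold higher number from compound 2 to compound 3 (0.30 log units; within the scatter) stay within the scatter, so no order among these three can be read from them; only the step of a 2.9-fold lower number from compound 1 to compound 2 (0.46 log units; beyond the scatter) lies beyond it. Compound 4 `O=C(NCCCCn1cccn1)c1cccc(C2SCC(=O)N2c2cc(F)ccn2)c1` differs from compound 3 by fluoro in place of methyl on an aromatic carbon. Among the compounds with values here, the one measured step that touches this carbon is a 2.0-fold higher number from compound 2 to compound 3 (0.30 log units; within the scatter), and no measured compound carries fluoro there. Compound 4 is therefore expected to show a step of a 1.3-fold lower number from compound 3 to compound 4 (0.11 log units; within the scatter), a small change not clearly beyond the scatter, with an estimated value of 800 mL.min-1.g-1 in the range 400 mL.min-1.g-1 to 1600 mL.min-1.g-1.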

Compound 4, intrinsic clearance in microsomes: 1200 mL.min-1.g-1
Beside the measured number, compound 4's estimate is 1.5-fold (0.18 log units) below it; low and high end bracket the measured number.
By their numbers in this assay, from the lowest: compounds 2, 3, 4 and 1 (each within the scatter of the next, the first and the last beyond it).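

In this assay, fluoro opposite the ring nitrogen cannot be told from methyl there, with a 1.2-fold higher number from compound 3 to compound 4 (0.07 log units; within the scatter) staying within the scatter. Set against hydrogen at this carbon, fluoro gives a 2.4-fold higher number from compound 2 to compound 4 (0.38 log units; beyond the scatter), a modest step beyond the scatter, which the methyl step from hydrogen did not reach. With a 1.2-fold lower number from compound 1 to compound 4 (0.09 log units; within the scatter), the 4-fluoropyridin-2-yl group also stays within the scatter of 5-fluoro-2-methoxyphenyl. Nothing given here explains these steps. On these data alone, whether a methoxy group or an amine at this carbon would stay as close to hydrogen or to fluoro remains open.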